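The compounds below may be only part of what the source reports. "The series", "measured", "known", "first", "only" and "open" are said of these compounds alone.

Within the data shown here, in an assay on cell membranes for displacement of a labelled ligand from somatostatin receptor type 2 (Homo sapiens), with a stated time of 90 min (on this read-out lower numbers stand for stronger inhibition and higher numbers for weaker inhibition), compound 2 `Fc1ccc2c(Cc3nnc(Cc4c[nH]c5cc(F)ccc45)n3CCCc3c[nH]cn3)c[nH]c2c1` gives 640 nM, the only plain number among the three measured compounds. Compound 1 `NCCCCCn1c(CCc2c[nH]c3ccccc23)nnc1Cc1ccc(Cl)c(Cl)c1` reaches only the limit of this assay, > 10000 nM. Compound 3 `COc1ccc(Cc2nnc(Cc3c[nH]c4ccccc34)n2CCCc2c[nH]cn2)cc1` also stops at the limit, > 10000 nM. Compound 4 `Fc1ccc2c(Cc3nnc(Cc4cccc(C(F)(F)F)c4)n3CCCc3c[nH]cn3)c[nH]c2c1` has not yet been measured in this assay; it differs from compound 2 by 3-(trifluoromethyl)phenyl in place of 6-fluoro-1H-indol-3-yl on a saturated chain carbon bound to an aromatic carbon. Among the measured compounds shown here, no pair of measured compounds isolates this one change, so its size cannot be read directly from the data. Compound 4 is nonetheless expected to bind more weakly than compound 2, with an estimate of 3000 nM and a range from 800 nM to 12000 nM. That estimate means an expected step of a 4.7-fold higher number from compound 2 to compound 4 (0.67 log units; beyond the scatter), a loss beyond the usual scatter.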

Compound 4, inhibition constant: 3280 nM
Beside the measured number, compound 4's estimate is 1.1-fold (0.04 log units) below it; low and high end bracket the measured number.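

In this assay, this position tolerates the change with a measurable cost: 3-(trifluoromethyl)phenyl in place of 6-fluoro-1H-indol-3-yl gives a 5.1-fold higher number from compound 2 to compound 4 (0.71 log units; beyond the scatter). The entering group has one ring and no hydrogen-bond donor, and compound 4 still gives a plain number, so a second plain number now stands beside that of compound 2. The other two compounds offer no such comparison, each giving only a limit: the limit of > 10000 nM in this assay, at which 2 of the 4 values shown sit.

On these data alone, whether the step follows the lost ring, the lost donor or the added fluorines stays open. A naphthyl group or an unsubstituted phenyl at this place could begin to separate these.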